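The source may report more compounds than this note shows. Statements on the series, on what has been measured and on what is new or still open speak of the compounds shown alone.

Of the compounds shown here, three sharing one core have been measured in an assay on cells for agonist activity at ecdysone receptor (Bombyx mori), read by a luciferase reporter, with a stated time of 24 h; a lower number here means that less compound is needed, a higher number that more compound is needed for the effect. Compound 1 `CC(C)(C)N(NC(=O)c1ccccc1)C(=O)c1ccccc1Cl` gives 75.9 nM. Compound 2 `CCc1ccccc1C(=O)N(NC(=O)c1ccccc1)C(C)(C)C` gives 589 nM, and compound 3 `CC(C)(C)N(NC(=O)c1ccccc1)C(=O)c1ccc(Cl)cc1Cl` gives 117 nM. On the numbers as written, compound 3 stands second highest of the three: the step of a 1.5-fold higher number from compound 1 to compound 3 (0.19 log units; within the scatter) lies within the scatter, while a 5.0-fold lower number from compound 2 to compound 3 (0.70 log units; beyond the scatter) lies beyond it.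

Compound 4 `CC(C)(C)N(NC(=O)c1ccccc1)C(=O)C1CCCCC1` has not yet been measured. It differs from compound 3 in one place: cyclohexyl in place of 2,4-dichlorophenyl on a carbonyl carbon. The measured steps all alter groups on that same ring attached to the carbonyl carbon: a 7.8-fold higher number from compound 1 to compound 2 (0.89 log units; beyond the scatter) and a 5.0-fold lower number from compound 2 to compound 3 (0.70 log units; beyond the scatter) were modest and beyond the scatter, whereas a 1.5-fold higher number from compound 1 to compound 3 (0.19 log units; within the scatter) stayed within it. Within the data shown here, none of them exchanges the aromatic ring for a non-aromatic one, so there is no direct precedent for this change.

Since changes at this position have so far shifted this assay only modestly, compound 4 is expected to show a modest rise, a 4.3-fold higher number from compound 3 to compound 4 (0.63 log units; beyond the scatter), with wide uncertainty. The estimate for compound 4 is 500 nM, ranging from 100 nM to 3000 nM.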

Compound 4, half-maximal effective concentration: 46800 nM
Compound 4: middle estimate off by 94-fold (1.97 log units), on the low side; measured number outside the range, above it.
By their numbers in this assay, from the lowest: compounds 1 and 3 (each within the scatter of the next); then compound 2; then compound 4.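

Replacing the aromatic ring on this carbonyl carbon with a non-aromatic one matters far more in this assay than any change among the aromatic groups shown: the steps to cyclohexyl are all large, with a 400-fold higher number from compound 3 to compound 4 (2.60 log units; beyond the scatter) and a 79-fold higher number from compound 2 to compound 4 (1.90 log units; beyond the scatter) and also a 620-fold higher number from compound 1 to compound 4 (2.79 log units; beyond the scatter). The earlier steps shown here at this position were modest at most, so they gave no sign of how sensitive it would be to this exchange. Nothing available here explains why the cyclohexyl compound needs so much more material for the effect.

The compounds shown leave open whether the aromatic ring itself is what counts, or whether a 2-chlorocyclohexyl group would bring the number back down. They also leave open how a different aromatic ring, such as pyridyl, would behave here.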